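The source may hold more compounds than are shown below. What is called first, only, known or untested is meant among the compounds shown, and "the series" means these compounds.

Measured in a functional assay on Huh-7 cells (Homo sapiens) for inhibition, read by CCK-8 assay, with a stated time of 72 h; on this read-out higher numbers stand for weaker inhibition and lower numbers for stronger inhibition:
compound 1 `O=C(/C=C/c1cccnc1)NCCCCCc1ccc(S(=O)(=O)Nc2ccccc2)cc1` gives 408 nM
compound 2 `Cc1ccccc1NS(=O)(=O)c1cccc(CCCCCCNC(=O)/C=C/c2cccnc2)c1` gives 0.525 nM
compound 3 `Cc1ccc(C)c(NS(=O)(=O)c2cccc(CCCCCCNC(=O)/C=C/c3cccnc3)c2)c1` gives 2.58 nM

Compound 3, at 2.58 nM, holds the second highest of the three numbers, above compound 2 and below compound 1. The next compound, compound 4 `O=C(/C=C/c1cccnc1)NCCCCCCc1cccc(S(=O)(=O)Nc2ccc(F)c(Cl)c2)c1`, has 3-chloro-4-fluorophenyl in place of 2,5-dimethylphenyl on a sulfonamide nitrogen. Going by the values given here, no measured step makes this exchange. The closest evidence is a 4.9-fold higher number from compound 2 to compound 3 (0.69 log units; beyond the scatter), a modest step beyond the scatter that also changes the group on the sulfonamide nitrogen. That single step shows that the number can respond to a small change in this group, but it gives no direction for the present exchange. Among the compounds with values here, compound 1 differs from compound 3 in more than one place and offers no guide to this step. In this assay, no step beyond the scatter is therefore expected, though with wide uncertainty. The expected step is a 1.2-fold higher number from compound 3 to compound 4 (0.07 log units; within the scatter), an estimate only. For compound 4 the estimated value is 3 nM, with an expected range of 0.6 nM to 15 nM.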

Compound 4, half-maximal inhibitory concentration: 39.4 nM
For compound 4 the middle estimate is 13-fold (1.12 log units) below the measured one; measured number above the stated range.
By their numbers in this assay, from the lowest: compound 2; then compound 3; then compound 4; then compound 1.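

In this assay, going by these compounds alone, the group on the sulfonamide nitrogen proves able to move the number much further than the one earlier step there suggested: a 15-fold higher number from compound 3 to compound 4 (1.18 log units; beyond the scatter), and a 75-fold higher number from compound 2 to compound 4 (1.88 log units; beyond the scatter), both large steps. The 2,5-dimethylphenyl and 3-chloro-4-fluorophenyl groups match in heavy atoms, hydrogen-bond donors, hydrogen-bond acceptors and net charge, so these counts do not separate them, and the difference in the number lies in the identity and placement of the ring substituents. No measurement on hand gives a reason for the size of these steps.

Both halogens enter together, so the shares of the chlorine and the fluorine remain unresolved; 3-chlorophenyl and 4-fluorophenyl groups would divide them. Going by these compounds, how a methoxyphenyl group on the same nitrogen would read also remains open.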